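The source may report more compounds than this note shows. Statements on the series, on what has been measured and on what is new or still open speak of the compounds shown alone.

The measured compounds:
compound 1, `CN(C(=O)NC(=O)c1c(F)cccc1F)c1nc(C(F)(F)F)c(C(=O)N/N=C/c2cccc(C(F)(F)F)c2)s1`, in a functional assay on A549 cells (Homo sapiens) for inhibition, read by MTT assay, with a stated time of 72 h (on this read-out higher numbers stand for weaker inhibition and lower numbers for stronger inhibition), compound 1 gives 27.6 ug/mL
compound 2, `CN(C(=O)NC(=O)c1c(F)cccc1F)c1nc(C(F)(F)F)c(C(=O)N/N=C/c2ccccc2C(F)(F)F)s1`, in this assay compound 2 gives 17.9 ug/mL

Within the data shown here, compound 1 has the highest number of the two; the only other number, that of compound 2, lies close to it, the two being a 1.5-fold lower number from compound 1 to compound 2 (0.19 log units; within the scatter) apart. Among the measured compounds shown here, the one measured step therefore concerns the group on the carbon with a double bond to nitrogen, and it stayed within the scatter.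

Compound 3, `CN(C(=O)NC(=O)c1cccc(C(F)(F)F)c1)c1nc(C(F)(F)F)c(C(=O)N/N=C/c2cccc(C(F)(F)F)c2)s1`, differs from compound 1 elsewhere: 3-(trifluoromethyl)phenyl in place of 2,6-difluorophenyl on a carbonyl carbon. For the measured compounds named here, no measured pair touches this carbonyl-bound ring, so the single measured step does not bear on the change, and the data give no direction for it. On that footing the expectation for compound 3 is a number close to that of compound 1, with no step beyond the scatter, but with a wide range to reflect that nothing measured speaks to this site. Compound 3 is estimated at 27 ug/mL, between 9 ug/mL and 80 ug/mL. The expected step from compound 1 to compound 3 is a 1.0-fold lower number from compound 1 to compound 3 (0.01 log units; within the scatter).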

Compound 3, half-maximal inhibitory concentration: 8.16 ug/mL
For compound 3 the middle estimate is 3.3-fold (0.52 log units) above the measured one, and the stated range ends above it.
By their numbers in this assay, from the lowest: compound 3; then compounds 2 and 1 (each within the scatter of the next).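

In this assay, the ring on the carbonyl carbon, whose other neighbour is the amide-type nitrogen, proves to be a place where the number can move: 3-(trifluoromethyl)phenyl in place of 2,6-difluorophenyl gives a step beyond the scatter (a 3.4-fold lower number from compound 1 to compound 3 (0.53 log units; beyond the scatter)), although a modest one that rests on a single pair. The only earlier step (a 1.5-fold lower number from compound 1 to compound 2 (0.19 log units; within the scatter)) concerned the group on the carbon with a double bond to nitrogen and stayed within the scatter, so this is the first change among the compounds shown to exceed it. Nothing in the available data accounts for this shift.

Among these compounds, the single pair cannot separate the loss of the 2,6-difluoro pattern from the gain of the trifluoromethyl group, so it remains open which of the two carries the step. Also open, going by these compounds, are what a plain phenyl or a 3-methoxyphenyl group would give on this carbonyl carbon, and whether the step would hold with 2-(trifluoromethyl)phenyl on the carbon with a double bond to nitrogen.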